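Trimming Ethyl to Methyl on a Weak Binder

The source may report more compounds than this note shows. Statements on the series, on what has been measured and on what is new or still open speak of the compounds shown alone.

Compound 3, with the structure `CCc1cccc(CC)c1Nc1nc(C)nc(NCc2ccc(C(F)(F)F)cc2)n1`, was tested in an assay on isolated protein for binding affinity to corticotropin-releasing factor receptor 1 (Homo sapiens); on this read-out lower numbers stand for stronger inhibition and higher numbers for weaker inhibition. Compound 3 gives 55000 nM, the highest of the three numbers measured. Compound 2, `CCCN(CC1CC1)c1nc(C)nc(Nc2ccc(OC)cc2OC)n1`, gives 8000 nM, and compound 1, `C=CCN(CC=C)c1nc(C)nc(Nc2c(C)cc(C)cc2C)n1`, gives 115 nM; both gaps to compound 3 are beyond the usual scatter, so compound 3 is the weakest binder of the three in this assay. Compound 4, `Cc1nc(NCc2ccc(C(F)(F)F)cc2)nc(Nc2c(C)cccc2C)n1`, differs from compound 3 in one place: 2,6-dimethylphenyl in place of 2,6-diethylphenyl on a nitrogen on an aromatic ring. Within the data shown here, no two measured compounds differ only in this way, so there is no measured step to lean on, and compound 1 differs from compound 4 in more than one place, so its value cannot serve as a single-step guide. For compound 4, a 1.8-fold lower number from compound 3 to compound 4 (0.26 log units; within the scatter) is expected to be small, leaning toward stronger binding, and may well stay within the scatter. Compound 4 is expected to give about 30000 nM, in a range from 8000 nM to 100000 nM.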

Compound 4, inhibition constant: > 10000 nM
Compound 4 was reported as a limit; the forecaster's own chance of this, stated with the estimate: 15%; the middle value does not contradict the limit.
By their numbers in this assay, from the lowest: compound 1; then compound 2; then compound 3.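

In this assay compound 4 gives > 10000 nM, which is a limit and not a number. The change from compound 3 to compound 4 therefore cannot be read as a step. The compounds shown leave open whether 2,6-dimethylphenyl in place of 2,6-diethylphenyl changes binding at all, and in which direction.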